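Working notes on cytotoxicity in a shared-core series

The source may report more compounds than this note shows. Statements on the series, on what has been measured and on what is new or still open speak of the compounds shown alone.

Measured compounds:
compound 1 `N#CC1=C(NC(=O)C2CC2)N(c2ccc(S(N)(=O)=O)cc2)C2=C(C(=O)CCC2)C1c1ccc(Cl)cc1Cl` — 20%
compound 2 `Cc1ccc(C(=O)NC2=C(C#N)C(c3ccc(Cl)cc3Cl)C3=C(CCCC3=O)N2c2ccc(S(N)(=O)=O)cc2)cc1` — 20%
compound 3 `N#CC1=C(NC(=O)c2ccc([N+](=O)[O-])cc2)N(c2ccc(S(N)(=O)=O)cc2)C2=C(C(=O)CCC2)C1c1ccc(Cl)cc1Cl` — 40%

In a functional assay on Ehrlich cells (Mus musculus) for cytotoxicity, read by trypan blue exclusion, with a stated time of 2 h, tested at 10 ug/mL (on this read-out lower numbers stand for a weaker effect and higher numbers for a stronger effect at the one concentration tested), compound 3 stands highest of the three numbers, and both steps toward it lie beyond the scatter: a number 20 percentage points higher from compound 1 to compound 3 (beyond the scatter) and a number 20 percentage points higher from compound 2 to compound 3 (beyond the scatter), whereas no change at the digits printed from compound 1 to compound 2 (within the scatter). Only the 4-nitrophenyl carbonyl amide therefore lifted the read-out.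

Compound 4 `CCO/C=N/C1=C(C#N)C(c2ccc(Cl)cc2Cl)C2=C(CCCC2=O)N1c1ccc(S(N)(=O)=O)cc1` differs from compound 3 by a group of 5 heavy atoms (3 carbon, 1 nitrogen, 1 oxygen; no ring) in place of a group of 12 heavy atoms (7 carbon, 2 nitrogen, 3 oxygen; one six-membered aromatic ring of carbon only), on a double-bonded ring carbon. Within the data shown here, the amide that carried the higher number is removed altogether, and the group that enters has no measured counterpart. The two other amides both sat at the lower level, so a fall back to that level is expected rather than a further rise: the expected step is a number 20 percentage points lower from compound 3 to compound 4 (beyond the scatter). Compound 4 is thus estimated at 20%, with a range of 5% to 40%.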

Compound 4, a percentage reported as activity, at one concentration (the size of the read-out at that concentration, not a potency): 30%
Compound 4: middle estimate off by 10 percentage points, on the low side, within the range that was stated.
By their numbers in this assay, from the lowest: compounds 1, 2, 4 and 3 (each within the scatter of the next, the first and the last beyond it).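

At this double-bonded ring carbon, the amide is not needed to keep the read-out in this assay within the scatter of compound 3: the ring-free group of 5 heavy atoms, with 0 hydrogen-bond donors, gives a number 10 percentage points lower from compound 3 to compound 4 (within the scatter) and also a number 10 percentage points higher from compound 2 to compound 4 (within the scatter) and a number 10 percentage points higher from compound 1 to compound 4 (within the scatter) in the same series. Compound 4 therefore cannot be placed with either the 4-nitrophenyl amide or the two other amides, although those levels lie apart. Nothing available explains this result.

On these data alone, whether an amine or a carboxylic acid at this double-bonded ring carbon would read at the same level remains open. So does the effect of a longer chain in the entering group.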